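Hydrogen to Methyl at the Amine Chain: Estimating Compound 4

A few compounds are considered here, and "the series" means these few. Any claim that something is new, unique, unknown or untested is made for them only; others in the source may bear on it.

Compound 1 `COc1cc2sn(CCCN(C)Cc3ccccc3)c(=O)c2cc1OC` is tested in an assay on isolated protein for inhibition of Amine oxidase [flavin-containing] A (Homo sapiens), read by fluorescence, with a stated time of 30 min (on this read-out higher numbers stand for weaker inhibition and lower numbers for stronger inhibition), where compound 1 gives 6900 nM. Compound 2 `CCN(CCCn1sc2cc(OC)c(OC)cc2c1=O)Cc1ccccc1` differs from compound 1 by a single change (methyl in place of hydrogen on a saturated chain carbon bound to an amine nitrogen); in this assay compound 2 gives 9900 nM, so the step is a 1.4-fold higher number from compound 1 to compound 2 (0.16 log units; within the scatter). Compound 3 `COc1cc2sn(CCCCCCN(C)Cc3ccccc3)c(=O)c2cc1OC` differs from compound 1 in more than one place, and that difference between the two cores is not broken down here. In this assay compound 3 gives 23000 nM. For the measured compounds named here, compound 4 `CCN(CCCCCCn1sc2cc(OC)c(OC)cc2c1=O)Cc1ccccc1` has not yet been measured; it differs from compound 3 by methyl in place of hydrogen on a saturated chain carbon bound to an amine nitrogen, the same change as the one from compound 1 to compound 2, at the same place. Because the earlier step was a 1.4-fold higher number from compound 1 to compound 2 (0.16 log units; within the scatter), a similarly small step is expected here, a 1.3-fold higher number from compound 3 to compound 4 (0.12 log units; within the scatter). Compound 4 is therefore estimated at 30000 nM in this assay, most likely between 12000 nM and 75000 nM.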

Compound 4, half-maximal inhibitory concentration: 8200 nM
The estimate for compound 4 lay 3.7-fold (0.56 log units) above the measured number, and the stated range ends above it.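

In this assay, putting methyl in place of hydrogen on a saturated chain carbon bound to an amine nitrogen, which turns benzyl(methyl)amino into benzyl(ethyl)amino, gives a 2.8-fold lower number from compound 3 to compound 4 (0.45 log units; beyond the scatter). The same change did not carry over unchanged from one core to the other: the same change on two cores in this assay, a 1.4-fold higher number (0.16 log units; within the scatter) from compound 1 to compound 2 and a 2.8-fold lower number (0.45 log units; beyond the scatter) from compound 3 to compound 4, 4.0-fold (0.60 log units) apart, beyond the scatter of two such steps. So in this series, a step read on one core proved a poor guide to the same step on the other, but two steps cannot show what sets the difference or how the change would behave on a further core.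

The compounds shown leave open what a propyl group on the amine would do on either core. They also leave open whether a longer chain would keep the step seen with compound 4.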